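The source may hold more compounds than are shown below. What is called first, only, known or untested is meant among the compounds shown, and "the series" means these compounds.

Three compounds sharing one core and differing only in the aromatic group carried on an oxygen on a saturated carbon have been tested in an assay for inhibition of Thromboxane-A synthase (Homo sapiens), using microsomes; a higher number here means a weaker inhibitor, a lower number a stronger inhibitor. Compound 1 `CC(C)(Oc1ccccc1)C1OCC(C/C=C\CCC(=O)O)C(c2cccnc2)O1` gives 52 nM. Compound 2 `CSc1ccc(OC(C)(C)C2OCC(C/C=C\CCC(=O)O)C(c3cccnc3)O2)c([N+](=O)[O-])c1` gives 22 nM, and compound 3 `Cc1ccc(C#N)c(OC(C)(C)C2OCC(C/C=C\CCC(=O)O)C(c3cccnc3)O2)c1` gives 50 nM. Compound 3 therefore holds the second highest of the three numbers: the step of a 1.0-fold lower number from compound 1 to compound 3 (0.02 log units; within the scatter) lies within the scatter, whereas the step of a 2.3-fold higher number from compound 2 to compound 3 (0.36 log units; beyond the scatter) is modest but real. Going by the values given here, the single exchange that clearly moved the number was a 2.4-fold lower number from compound 1 to compound 2 (0.37 log units; beyond the scatter).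

Compound 4 `COc1ccc(OC(C)(C)C2OCC(C/C=C\CCC(=O)O)C(c3cccnc3)O2)cc1` has not yet been measured. It differs from compound 3 in that (4-methoxyphenyl in place of 2-cyano-5-methylphenyl on an oxygen on a saturated carbon). Among the compounds with values here, the steps that bear on this are the three exchanges of the aromatic group on that oxygen: one within the scatter and two modest ones, all pointing to a narrow spread for such swaps. Because the step of a 1.0-fold lower number from compound 1 to compound 3 (0.02 log units; within the scatter) showed that replacing phenyl by 2-cyano-5-methylphenyl left the number unchanged, and only the group of compound 2 lowered it, the 4-methoxyphenyl of compound 4 is expected to produce a step of a 1.1-fold lower number from compound 3 to compound 4 (0.05 log units; within the scatter), within the scatter. For compound 4 in this assay the estimated value is 45 nM, with a range from 18 nM to 110 nM.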

Compound 4, half-maximal inhibitory concentration: 41 nM
For compound 4 the middle estimate is 1.1-fold (0.04 log units) above the measured one; the range from low to high includes it.
By their numbers in this assay, from the lowest: compounds 2, 4, 3 and 1 (each within the scatter of the next, the first and the last beyond it).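

In this assay the simplest change so far, methoxy in place of hydrogen on an aromatic carbon, gives a 1.3-fold lower number from compound 1 to compound 4 (0.10 log units; within the scatter) and so leaves the plain phenyl group and the 4-methoxyphenyl group indistinguishable. Exchanging the 2-cyano-5-methylphenyl group for 4-methoxyphenyl gives a 1.2-fold lower number from compound 3 to compound 4 (0.09 log units; within the scatter) and is likewise too small to read, so on this oxygen two differently substituted rings and the unsubstituted one cannot be told apart. Compound 2 had seemed to stand apart from the others, but a 1.9-fold higher number from compound 2 to compound 4 (0.27 log units; within the scatter) also lies within the scatter, so compound 4 sits within the scatter of all three, and clear gaps remain only between compound 2 and compounds 1 and 3.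

No measurement at hand explains why these exchanges on the ring change the number so little. From the compounds shown here alone, it remains open whether a ring carrying an amine or a carboxylic acid, or a longer chain in place of the ring on this oxygen, would move the number further, and whether the nitro group or the methylthio group of compound 2 accounts for its lower number.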